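A few compounds are considered here, and "the series" means these few. Any claim that something is new, unique, unknown or untested is made for them only; others in the source may bear on it.

Working notes on the series. Two members have numbers in a functional assay on A549 cells (Homo sapiens) for cytotoxicity, read by MTT assay, with a stated time of 72 h (a higher number here means a weaker inhibitor, a lower number a stronger inhibitor), so far. Compound 1 `Cc1ccc(NC(=O)CN2CCN(c3nnc(Cc4ccncc4)c4ccccc34)CC2)c(C)c1` gives 45000 nM in this assay, the highest of the two numbers; compound 2 `O=C(CN1CCN(c2nnc(Cc3ccccc3)c3ccccc23)CC1)Nc1ccc(F)c(F)c1` gives 10100 nM in this assay, a gap beyond the scatter, though the two structures differ in more than one place, so no single change can be read from it.

The next compound, compound 3 `Cc1ccccc1NC(=O)CN1CCN(c2nnc(Cc3ccncc3)c3ccccc23)CC1`, differs from compound 1 by one change: hydrogen in place of methyl on an aromatic carbon. The change removes one carbon and no ring, donor or acceptor, at a position remote from the shared core.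

Nothing measured here isolates this change. With so small a difference, the expected step from compound 1 to compound 3, a 1.1-fold lower number from compound 1 to compound 3 (0.05 log units; within the scatter), is no more than the scatter, with no direction preferred. Compound 3 is therefore estimated at 40000 nM in this assay, with a range of 15000 nM to 100000 nM.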

Compound 3, half-maximal inhibitory concentration: 43100 nM
Beside the measured number, compound 3's estimate is 1.1-fold (0.03 log units) below it; the measured number falls inside the stated range.
By their numbers in this assay, from the lowest: compound 2; then compounds 3 and 1 (each within the scatter of the next).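

Within the data shown here, the first step that can be read at a single place, a 1.0-fold lower number from compound 1 to compound 3 (0.02 log units; within the scatter), is the change from 2,4-dimethylphenyl to 2-methylphenyl in this assay, and it lies within the scatter. At this position, para to a large group and with the other methyl group kept, methyl and hydrogen therefore cannot be told apart by their numbers, though this rests on a single pair. No supporting measurement bears on this result.

The compounds shown leave open whether a methoxy group or a carboxylic acid at this position would also give a number within the scatter of compound 3. What the remaining methyl group contributes is open too, as is whether the same replacement would read alike on a ring carrying fluorine.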